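The compounds below may be only part of what the source reports. "The series", "measured", "known", "first", "only" and "open" are said of these compounds alone.

Compound 1 `COc1cc(-n2ncnc2-c2cccc([N+](=O)[O-])c2)cc(OC)c1OC` carries a nitro group on an aromatic carbon of the six-membered aromatic ring of carbon only. In a functional assay on HL-60 cells (Homo sapiens) for antiproliferative activity, read by MTT assay, with a stated time of 72 h (a higher number here means a weaker inhibitor, a lower number a stronger inhibitor), compound 1 gives > 10000 nM, which is a limit of the assay and not a number. Compound 2 `COc1cc(-c2ncnn2-c2ccccc2)cc(OC)c1OC` likewise gives only a limit in this assay, > 10000 nM. Going by the values given here, compound 1 therefore stands at the limit of > 10000 nM in this assay, at which 2 of the 2 values shown sit, and no step between measured compounds can be drawn from these two values. Compound 3 `COc1cc(-n2ncnc2-c2cccc(F)c2)cc(OC)c1OC` differs from compound 1 by fluoro in place of nitro on an aromatic carbon. Among the compounds with values here, nothing among the measured compounds shows how this change acts in this assay, so no move beyond the scatter is expected in either direction. Compound 3 is expected to show a step that the limit leaves unreadable from compound 1 to compound 3 in this assay, which means compound 3 is estimated at 20000 nM, with a range of 5000 nM to 80000 nM, most likely reported again only as a limit.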

Compound 3, half-maximal inhibitory concentration: > 10000 nM
Compound 3: no number, only a limit; the forecaster's own chance of this, stated with the estimate: 70%; the middle value lies beyond the limit too.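

No step can be read between compound 1 and compound 3 in this assay, since both give only a limit and not a number: the limit of > 10000 nM in this assay, at which 3 of the 3 values shown sit. The compounds shown leave open whether fluoro in place of nitro changes antiproliferative activity at all.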